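A Single Ring Swap on the Carbonyl Carbon

The source may report more compounds than this note shows. Statements on the series, on what has been measured and on what is new or still open speak of the compounds shown alone.

Of the compounds shown here, two have so far been measured in a functional assay on A549 cells (Homo sapiens) for inhibition, read by MTT assay, with a stated time of 72 h; a lower number here means a stronger inhibitor, a higher number a weaker inhibitor. Compound 1 `CN(C(=O)NC(=O)c1ccc(F)c(F)c1)c1nc(C(F)(F)F)c(C(=O)N/N=C/c2ccccc2C(F)(F)F)s1` gives 6.96 ug/mL. Compound 2 `CN(C(=O)NC(=O)c1c(Cl)cccc1Cl)c1nc(C(F)(F)F)c(C(=O)N/N=C/c2ccccc2C(F)(F)F)s1` gives 12 ug/mL. Among the compounds with values here, the one step that links them, a 1.7-fold higher number from compound 1 to compound 2 (0.24 log units; within the scatter), puts 2,6-dichlorophenyl in place of 3,4-difluorophenyl on a carbonyl carbon and stays within the scatter. Within the data shown here, compound 2 therefore holds the higher of the two numbers, yet its only neighbour, compound 1, sits within the scatter of it, so no order between the two can be read from these figures.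

Compound 3 `CN(C(=O)NC(=O)c1ccccc1F)c1nc(C(F)(F)F)c(C(=O)N/N=C/c2ccccc2C(F)(F)F)s1` differs from compound 2 in a single place: 2-fluorophenyl in place of 2,6-dichlorophenyl on a carbonyl carbon. Among the measured compounds shown here, the only measured step that bears on this position is a 1.7-fold higher number from compound 1 to compound 2 (0.24 log units; within the scatter), and it was small. With no step beyond the scatter to draw on, the expected outcome is a number of the same order. In this assay compound 3 is expected to give 9 ug/mL, with a likely range from 4 ug/mL to 20 ug/mL. This amounts to an expected step of a 1.3-fold lower number from compound 2 to compound 3 (0.12 log units; within the scatter), which is none beyond the scatter.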

Compound 3, half-maximal inhibitory concentration: 6.32 ug/mL
Compound 3: middle estimate off by 1.4-fold (0.15 log units), on the high side, and the stated range covers the measured number.
By their numbers in this assay, from the lowest: compounds 3, 1 and 2 (each within the scatter of the next).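

Swapping 2,6-dichlorophenyl for 2-fluorophenyl on this carbonyl carbon, whose other neighbour is an amide-type nitrogen, gives a 1.9-fold lower number from compound 2 to compound 3 (0.28 log units; within the scatter) in this assay, so this second change at the position also stays inside the scatter. Within the data shown here, the step of a 1.1-fold lower number from compound 1 to compound 3 (0.04 log units; within the scatter) is smaller still, and it shows that 2-fluorophenyl and 3,4-difluorophenyl cannot be told apart here, so all three phenyl groups at this position now lie within the scatter of one another, where the earlier pair offered only a single comparison. No independent measurement is available to explain this lack of separation.

The three groups are all halogen-bearing phenyl rings, so the compounds shown leave open whether plain phenyl, or a phenyl carrying an amine or a carboxylic acid, would give a number beyond the scatter. They also leave open whether replacing the ring altogether with a longer alkyl chain on the same carbonyl carbon would move the number, and therefore how much of the shared activity depends on this position at all.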